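The source may report more compounds than this note shows. Statements on the series, on what has been measured and on what is new or still open speak of the compounds shown alone.

Measured so far:
compound 1 `N#Cc1cnc(NCc2cnccc2C(F)(F)F)cc1N[C@H]1C[C@H](O)C1` — 900 nM
compound 2 `N#Cc1cnc(NCc2ccccc2C(F)(F)F)cc1N[C@H]1CC[C@H](O)CC1` — 4000 nM
compound 3 `N#Cc1cnc(NCc2cnccc2C(F)(F)F)cc1NCC1CCOCC1` — 400 nM

In an assay on isolated protein for inhibition of protein kinase C theta type (Homo sapiens), read by TR-FRET, with a stated time of 2 h (on this read-out higher numbers stand for weaker inhibition and lower numbers for stronger inhibition), compound 2 has the highest number of the three, with compound 1 nearest and compound 3 furthest from it. Compound 4 `N#Cc1cnc(NCc2ccccc2C(F)(F)F)cc1N[C@H]1C[C@H](C(N)=O)C1` differs from compound 2 in one place: 3-carbamoylcyclobutyl in place of 4-hydroxycyclohexyl on a nitrogen on an aromatic ring. Among the compounds with values here, no measured step covers this change. Within the data shown here, the only step among the measured compounds, a 2.3-fold lower number from compound 1 to compound 3 (0.35 log units; beyond the scatter), concerns a different position and says little about it. Compound 1 and compound 2 differ in two places, so their values can only be compared as they stand: compound 1 carries a 3-hydroxycyclobutyl group and gives 900 nM, while compound 2 carries a 4-hydroxycyclohexyl group and gives 4000 nM. That comparison gives a weak hint that a four-membered ring on this nitrogen may go with a lower number than the six-membered one, but the second difference between them makes this uncertain. For compound 4 a modest improvement is therefore expected, a step of a 2.0-fold lower number from compound 2 to compound 4 (0.30 log units; within the scatter), giving an estimated 2000 nM with a range from 600 nM to 7000 nM.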

Compound 4, half-maximal inhibitory concentration: 5000 nM
Estimate against measurement, compound 4: 2.5-fold (0.40 log units) below; the measured number falls inside the stated range.
By their numbers in this assay, from the lowest: compound 3; then compound 1; then compounds 2 and 4 (each within the scatter of the next).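

In this assay, within the data shown here, the step from the six-membered to the four-membered ring, a 1.3-fold higher number from compound 2 to compound 4 (0.10 log units; within the scatter), gives the first direct reading at this nitrogen on the core of compound 2. Exchanging 4-hydroxycyclohexyl for 3-carbamoylcyclobutyl leaves the number within the scatter, so this pair gives no support to the weak hint that a four-membered ring here goes with a lower number. Ring size and the group on the ring change together in this step, and the pair cannot separate the two. Nothing available explains this result. The compounds shown leave open what each of those two changes does alone, and how a 3-aminocyclobutyl or 3-carboxycyclobutyl group, with an amine or a carboxylic acid in place of the carbamoyl group, would read on this nitrogen.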